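The compounds below may be only part of what the source reports. "The series", "measured", "known", "first", "only" and "open" are said of these compounds alone.

Compound 1 `C[C@@H](CCCN1CCCC1)Nc1ccnc2cc(Cl)ccc12` gives 180000 nM in an assay for binding affinity, read by spectrophotometry; a higher number here means a weaker inhibitor, a lower number a stronger inhibitor.
Compound 2 `C[C@H](CCCN1CCCCC1)Nc1ccnc2cc(Cl)ccc12` gives 130000 nM in this assay.
Compound 3 `C[C@@H](CCCN1CCCCC1)Nc1ccnc2cc(Cl)ccc12` gives 150000 nM in this assay.

Compound 3 stands second of the three numbers in this assay, with compounds 1 and 2 so close on either side that the three cannot be told apart. Compound 4 `C[C@@H](CCCNC(C)(C)C)Nc1ccnc2cc(Cl)ccc12` has not yet been measured. Its structure differs from compound 3 in one place: (tert-butyl)amino in place of piperidin-1-yl on a saturated chain carbon, four bonds along the chain from a nitrogen on an aromatic ring. Among the measured compounds shown here, two measured steps bear on this chain end. a 1.2-fold lower number from compound 1 to compound 3 (0.08 log units; within the scatter) shows that enlarging the ring at this end changed nothing that can be trusted, and a 1.2-fold higher number from compound 2 to compound 3 (0.06 log units; within the scatter) shows the same for the drawn configuration of the chain, a comparison that rests on (the fact that compounds 2 and 3 differ only in the configuration as drawn). For the measured compounds named here, neither step moved beyond the scatter, so no measured step points in a clear direction for the change to compound 4. The step of a 1.1-fold higher number from compound 3 to compound 4 (0.03 log units; within the scatter) is therefore expected to stay within the scatter. Compound 4 is estimated to give 160000 nM in this assay, with a range from 60000 nM to 400000 nM.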

Compound 4, half-maximal inhibitory concentration: 150000 nM
Beside the measured number, compound 4's estimate is 1.1-fold (0.03 log units) above it, within the range that was stated.
By their numbers in this assay, from the lowest: compounds 2, 3, 4 and 1 (each within the scatter of the next).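

Replacing piperidin-1-yl with (tert-butyl)amino gives no change at the digits printed from compound 3 to compound 4 (within the scatter) in this assay, and replacing pyrrolidin-1-yl with the same group gives a 1.2-fold lower number from compound 1 to compound 4 (0.08 log units; within the scatter). Among the compounds shown here, the earlier compounds compared only two ring sizes at this chain end, whereas the group that enters here has no ring and carries a hydrogen-bond donor, which piperidin-1-yl lacks, so this position has now tolerated an open group as well as a ring without a change beyond the scatter. Nothing in the information available bears on why this change leaves the number within the scatter.

On these data alone, whether a carboxylic acid or a primary amine at this chain end, or a longer chain leading to it, would move the number beyond the scatter remains open. So does the effect of the opposite drawn configuration with (tert-butyl)amino in place.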